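A few compounds are considered here, and "the series" means these few. Any claim that something is new, unique, unknown or untested is made for them only; others in the source may bear on it.

Measured compounds:
Compound 1 `O=c1[nH]cc(S(=O)(=O)Nc2ccccc2-c2cn(-c3ccccc3F)nn2)c(=O)[nH]1` gives 15300 nM in a functional assay on OVCAR-3 cells (Homo sapiens) for antiproliferative activity, read by MTT assay, with a stated time of 24 h; a lower number here means a stronger inhibitor, a higher number a weaker inhibitor.
Compound 2 `O=c1[nH]cc(S(=O)(=O)Nc2ccccc2-c2cn(-c3ccccc3Cl)nn2)c(=O)[nH]1` gives 3170 nM in this assay.
Compound 3 `Cc1ccccc1-n1cc(-c2cccc(NS(=O)(=O)c3c[nH]c(=O)[nH]c3=O)c2)nn1` gives 6230 nM in this assay.

Among these three numbers, compound 3 stands second highest. Its nearest neighbour is compound 2, and the two lie within the usual scatter of each other; compound 1 lies further off, and that gap is beyond the scatter. For the measured compounds named here, the only step within the set is a 4.8-fold lower number from compound 1 to compound 2 (0.68 log units; beyond the scatter), an exchange of one halogen for another on the ring that carries it.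

Compound 4 `O=c1[nH]cc(S(=O)(=O)Nc2cccc(-c3cn(-c4ccccc4F)nn3)c2)c(=O)[nH]1` differs from compound 3 by fluoro in place of methyl on an aromatic carbon. Going by the values given here, no measured pair trades methyl for fluoro, so the step from compound 3 to compound 4 has no direct precedent. What the set does show is that the fluoro-bearing compound 1 gives the highest number of the three, while compound 2 with chloro sits well below it. On that basis a move toward a higher number is expected, with a 1.9-fold higher number from compound 3 to compound 4 (0.28 log units; within the scatter) as the estimated step. Compound 4 is therefore expected at about 12000 nM, within a range from 4000 nM to 40000 nM.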

Compound 4, half-maximal inhibitory concentration: 12500 nM
The estimate for compound 4 lay 1.0-fold (0.02 log units) below the measured number, and the stated range covers the measured number.
By their numbers in this assay, from the lowest: compounds 2, 3, 4 and 1 (each within the scatter of the next, the first and the last beyond it).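

In this assay the exchange of methyl for fluoro on the ring, ortho to a large group, gives a step within the scatter (a 2.0-fold higher number from compound 3 to compound 4 (0.30 log units; within the scatter)). For the compounds shown here, the assay therefore does not separate 2-methylphenyl from 2-fluorophenyl on the core of compound 3, something the earlier compounds could not show, as none of them paired these two groups. The only halogen exchange shown, on the core of compound 1, lies beyond the scatter (a 4.8-fold lower number from compound 1 to compound 2 (0.68 log units; beyond the scatter)), so at this place on the ring not every single-atom exchange is equally silent, although that step belongs to a different core.

On these data alone, it remains open whether chloro on the core of compound 3 would repeat that halogen step, and how a methoxy group, an amine or a carboxylic acid would read at this place. Nothing shown here offers an account of why these numbers fall as they do.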